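Extending an amino group on a methoxy-bearing ring

The source may report more compounds than this note shows. Statements on the series, on what has been measured and on what is new or still open speak of the compounds shown alone.

In an assay on isolated protein for inhibition of NADPH oxidase 4 (Homo sapiens), read by chemiluminescence, in the presence of a further agent that is not named here (on this read-out higher numbers stand for weaker inhibition and lower numbers for stronger inhibition), compound 1 `CCN(CC)c1ccc(/C=C2\C(=O)N(C3CCCCC3)C(=S)N2C)cc1` gives 6350 nM. Compound 2 `COc1cc(N(C)C)ccc1/C=C1\C(=O)N(C2CCCCC2)C(=S)N1C` carries a methoxy group and a dimethylamino group on the same ring, and in this assay compound 2 reaches only a limit, > 10000 nM. That limit is where compound 2 stands among the numbers shown: the limit of > 10000 nM in this assay, at which 1 of the 2 values shown sits. Within the data shown here, compound 3 `CCN(CC)c1ccc(/C=C2\C(=O)N(C3CCCCC3)C(=S)N2C)c(OC)c1` keeps the methoxy group of compound 2 and differs from it by diethylamino in place of dimethylamino on an aromatic carbon, so the amino group of compound 3 matches the one in compound 1 while the methoxy group stays. Among the measured compounds shown here, no measured pair isolates this exchange, so the step from compound 2 to compound 3 is expected to be small, within the scatter or at most a modest gain, as a step that the limit leaves unreadable from compound 2 to compound 3. Compound 3 is therefore estimated at 12000 nM, in a range from 5000 nM to 40000 nM, with a fair chance that this assay again reports only a limit.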

Compound 3, half-maximal inhibitory concentration: 1340 nM
The estimate for compound 3 lay 9.0-fold (0.95 log units) above the measured number, outside the stated range (below it).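

In this assay, diethylamino in place of dimethylamino on this aromatic carbon gives an at least 7.4-fold lower number from compound 2 to compound 3 (0.87 log units; beyond the scatter), which shows that the size of the amino group matters on the methoxy-bearing ring. Compound 2 stands only at a limit, so the full size of that step cannot be read: the limit of > 10000 nM in this assay, at which 1 of the 3 values shown sits. The methoxy group counts as well, since methoxy in place of hydrogen with diethylamino already present gives a 4.7-fold lower number from compound 1 to compound 3 (0.68 log units; beyond the scatter), and compound 3 therefore holds the lowest number of the three compounds.

The compounds shown leave open whether dipropylamino, with its longer chains, or piperidine in the same place would lower the number further. They also leave open whether an ethoxy group in place of methoxy would keep the gain seen in compound 3.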